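The source may hold more compounds than are shown below. What is called first, only, known or untested is meant among the compounds shown, and "the series" means these compounds.

Values in an ADME assay on MDBK cells (Bos taurus) for cytotoxicity, read by MTT assay, with a stated time of 96 h; on this read-out higher numbers stand for lower toxicity in this test and lower numbers for higher toxicity in this test:
compound 1 `Cc1ccc(/N=N/c2ccc(NCCCN(C)C)cc2)cc1`: > 100000 nM
compound 2 `c1ccc(/N=N/N2CCCCC2)cc1`: > 100000 nM
compound 3 `FC(F)(F)c1cccc(/N=N/N2CCCC2)c1`: > 100000 nM

Each entry is a limit of the assay and not a number. Compound 1 stands with compounds 2 and 3 at the limit of > 100000 nM in this assay, at which 3 of the 3 values shown sit. No order among the three can be drawn.

Compound 4 `CN(C)CCCNc1ccc(/N=N/c2ccccc2)cc1` is the next to be read in this assay. It differs from compound 1 in one place: hydrogen in place of methyl on an aromatic carbon. Within the data shown here, no measured pair differs in one place, so the size of this change has not been observed directly. The expectation rests on compound 1, whose value > 100000 nM is a limit. The expected result a number no higher from compound 1 to compound 4 (the limit leaves the size open) is no step beyond the scatter, and any departure is expected to run towards lower numbers. For compound 4 the estimated value is 100000 nM, with an expected range of 35000 nM to 100000 nM.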

Compound 4, half-maximal cytotoxic concentration: 58000 nM
Compound 4: the middle estimate sits 1.7-fold (0.24 log units) above what was measured, and the stated range covers the measured number.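

Among these compounds, compound 4 gives the first reading in this assay that is a number and not a limit, so this position on the core of compound 1 now has a measured result. Hydrogen in place of methyl on this aromatic carbon, para to a large group, gives an at least 1.7-fold lower number from compound 1 to compound 4 (0.23 log units; that floor lies within the scatter), and the upper size of the step stays open, so it cannot be said whether the 4-methylphenyl to phenyl change goes beyond the scatter. The rest of the series gives no further number for comparison: the limit of > 100000 nM in this assay, at which 3 of the 4 values shown sit.

Open, as far as these compounds go, is how other groups on this same aromatic carbon, such as methoxy, chlorine or a carboxylic acid, would read in this assay. Also open, from the compounds shown here alone, is whether a longer chain or a morpholine in place of the dimethylamino end would shift the number for compound 4.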